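The source may report more compounds than this note shows. Statements on the series, on what has been measured and on what is new or still open speak of the compounds shown alone.

Compound 1 `O=C(O)CCn1c(=O)oc2cc(OCc3ccccc3)c(Cl)cc21`: 1580 nM; compound 2 `Cc1ccnc([C@@H](C)Oc2cc3oc(=O)n(CCC(=O)O)c3cc2Cl)c1`: 31600 nM; compound 3 `CCOc1cc2oc(=O)n(CCC(=O)O)c2cc1Cl`: 398 nM.

In an assay on HEK293 cells for inhibition of kynurenine 3-monooxygenase (Homo sapiens), read by LC-MS, with a stated time of 20 h (a higher number here means a weaker inhibitor, a lower number a stronger inhibitor), compound 1 gives 1580 nM, the second highest of the three numbers; compound 3 sits nearest, at a 4.0-fold lower number from compound 1 to compound 3 (0.60 log units; beyond the scatter), while compound 2 stands furthest, with a much higher number. Compound 4 `C[C@@H](Oc1cc2oc(=O)n(CCC(=O)O)c2cc1Cl)c1ncco1` differs from compound 1 by a group of 7 heavy atoms (5 carbon, 1 nitrogen, 1 oxygen; one five-membered aromatic ring with 2 hetero atoms) in place of a group of 7 heavy atoms (7 carbon; one six-membered aromatic ring of carbon only), on an oxygen on an aromatic ring. For the measured compounds named here, two measured steps bear on this: a 4.0-fold lower number from compound 1 to compound 3 (0.60 log units; beyond the scatter) and a 79-fold lower number from compound 2 to compound 3 (1.90 log units; beyond the scatter). Compound 2, which carries 4-methylpyridin-2-yl on the saturated chain carbon bound to the oxygen, is far weaker than compound 1. Compound 4 carries a five-membered aromatic ring with 2 hetero atoms at that carbon, so a step toward a higher number, smaller than that seen for compound 2, is expected: a 3.2-fold higher number from compound 1 to compound 4 (0.50 log units; beyond the scatter). Compound 4 is therefore estimated at 5000 nM, within 1600 nM to 16000 nM.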

Compound 4, half-maximal inhibitory concentration: 7940 nM
Beside the measured number, compound 4's estimate is 1.6-fold (0.20 log units) below it, and the stated range covers the measured number.
By their numbers in this assay, from the lowest: compound 3; then compound 1; then compound 4; then compound 2.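

In this assay, placing 1,3-oxazol-2-yl on the saturated chain carbon gives a 20-fold higher number from compound 3 to compound 4 (1.30 log units; beyond the scatter) and so shows that this ring is poorly tolerated there, while replacing benzyl on the oxygen gives a 5.0-fold higher number from compound 1 to compound 4 (0.70 log units; beyond the scatter) as a smaller rise. Replacing 4-methylpyridin-2-yl with 1,3-oxazol-2-yl gives a 4.0-fold lower number from compound 2 to compound 4 (0.60 log units; beyond the scatter) at the same carbon, so the identity of the ring changes the size of the loss. No evidence is available to explain these steps. Going by these compounds, it remains open whether a longer alkyl chain or an amine on that carbon would match compound 3, and whether a phenyl ring there would behave like either of these two rings.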